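Ortho substituent swap on the dienone series

The source may report more compounds than this note shows. Statements on the series, on what has been measured and on what is new or still open speak of the compounds shown alone.

Measured compounds:
- compound 1 `CC1=C(/C=C/C(=O)/C=C/c2ccccc2)C(C)(C)CCC1`: 62200 nM
- compound 2 `CC1=C(/C=C/C(=O)/C=C/c2ccccc2Cl)C(C)(C)CCC1`: 54200 nM

Both numbers come from a functional assay on Hep cells (Homo sapiens) for cytotoxicity, read by sulforhodamine B assay, with a stated time of 48 h; a lower number here means a stronger inhibitor, a higher number a weaker inhibitor. Among the measured compounds shown here, compound 2 and compound 1 sit within the scatter of each other; the only measured step, a 1.1-fold lower number from compound 1 to compound 2 (0.06 log units; within the scatter), adds chloro on an aromatic carbon and does not move the number beyond the scatter.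

Compound 3 `CC1=C(/C=C/C(=O)/C=C/c2ccccc2C)C(C)(C)CCC1` is not yet measured. Its difference from compound 2 is methyl in place of chloro on an aromatic carbon. For the measured compounds named here, the one measured step bears on it only loosely: it shows that putting chloro on that aromatic carbon left this assay unchanged within the scatter, which gives no reason to expect that exchanging chloro for methyl at the same aromatic carbon will move the number beyond the scatter either. Compound 3 is therefore expected to give about 55000 nM in this assay, with a range from 25000 nM to 120000 nM. The expected step of a 1.0-fold higher number from compound 2 to compound 3 (0.01 log units; within the scatter) is within the scatter.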

Compound 3, half-maximal inhibitory concentration: 41000 nM
For compound 3 the middle estimate is 1.3-fold (0.13 log units) above the measured one, within the range that was stated.
By their numbers in this assay, from the lowest: compounds 3, 2 and 1 (each within the scatter of the next).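

Exchanging chloro for methyl on this aromatic carbon, ortho to a large group, stays within the scatter in this assay (a 1.3-fold lower number from compound 2 to compound 3 (0.12 log units; within the scatter)), and methyl in place of hydrogen at the same carbon does too (a 1.5-fold lower number from compound 1 to compound 3 (0.18 log units; within the scatter)). Among the compounds shown here, compound 3 thus extends the reading from a single chloro step: across hydrogen, chloro and methyl at this carbon, no step printed for the three compounds lies beyond the scatter. No measurement shown here explains this result.

From the compounds shown here alone, whether a different kind of group on this carbon, such as an amine, a carboxylic acid or a longer chain, would move the number beyond the scatter remains open. Also open, going by these compounds, is whether chloro or methyl elsewhere on the aromatic ring would behave the same way.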